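The compounds below may be only part of what the source reports. "The series", "measured", "known", "first", "only" and "open" are said of these compounds alone.

Two measured compounds share a core that carries two halogen-bearing aryl groups. Compound 1 `CN1C/C(=C\c2ccc(Br)cc2)C(=O)[C@]2(C1)[C@@H](c1ccc(Br)cc1)CN(C)[C@@]21C(=O)Nc2ccccc21` is the dibromo member; in a functional assay on the whole organism (strain Wister albino) for inhibition, with Rattus norvegicus as the target, read by paw edema, with a stated time of 1 h, at a dose of 50 mg/kg by the intraperitoneal route (a higher number here means more inhibition at the dose given (going by the name of the read-out), a lower number less inhibition), compound 1 gives 77.7%. Compound 2 `CN1C/C(=C\c2ccc(Cl)cc2)C(=O)[C@]2(C1)[C@@H](c1ccc(Cl)cc1)CN(C)[C@@]21C(=O)Nc2ccccc21` is the dichloro member; in this assay compound 2 gives 83.1%. The two numbers lie within the usual scatter of one another, so nothing separates them, and compound 2 is taken as the reference point for the next step. Compound 3 `CN1C/C(=C\c2ccc(Cl)cc2)C(=O)[C@]2(C1)[C@@H](c1ccc(Cl)cc1)CN(C)[C@@]21C(=O)N(C)c2ccccc21` differs from compound 2 in one place: methyl in place of hydrogen on an amide-type nitrogen in a ring. Going by the values given here, no measured pair carries this change, so its effect is unknown from the data. With only the two values above to go on, the step from compound 2 to compound 3 in this assay is expected to be small, with no direction beyond the scatter, a number 5.1 percentage points lower from compound 2 to compound 3 (within the scatter). For compound 3 in this assay the estimate is 78%, with a range from 62% to 90%.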

Compound 3, a percentage reported as inhibition, in the whole organism at one dose (the size of the read-out at that dose, not a potency): 82.3%
Estimate against measurement, compound 3: 4.3 percentage points below; low and high end bracket the measured number.
By their numbers in this assay, from the lowest: compounds 1, 3 and 2 (each within the scatter of the next).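

In this assay, going by these compounds alone, methyl in place of hydrogen on the amide-type nitrogen in a ring gives a number 0.8 percentage points lower from compound 2 to compound 3 (within the scatter), the first direct reading of this change. For this pair, the amide hydrogen is therefore not required to keep the inhibition read at this dose, and the position accepts a methyl without a step beyond the scatter. Nothing available explains this result or ties it to any property of the group.

From the compounds shown here alone, whether the position also accepts an ethyl, a benzyl or a longer chain ending in an amine or a carboxylic acid remains open. The read-out gives the size of the effect at a single dose, so any difference in potency between compound 2 and compound 3 also stays unresolved, as does the effect of the methyl on the dibromo compound 1.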